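The compounds below may be only part of what the source reports. "The series", "measured", "known", "first", "only" and "open" are said of these compounds alone.

Measured compounds:
- compound 1 `Cc1cc(O)c(C(C)C)cc1-c1cc(-c2ccccc2)c(C#N)c(=O)[nH]1`, in a functional assay for inhibition, tested at 20 ug/mL (on this read-out higher numbers stand for a stronger effect at the one concentration tested and lower numbers for a weaker effect), compound 1 gives 22%
- compound 2 `COc1ccc(-c2cc(-c3cc(C(C)C)c(O)cc3C)[nH]c(=O)c2C#N)c(OC)c1`, in this assay compound 2 gives 27%
- compound 3 `Cc1cc(O)c(C(C)C)cc1-c1cc(-c2ccc(N(C)C)cc2)c(C#N)c(=O)[nH]1`, in this assay compound 3 gives 30%

Compound 3 holds the highest of the three numbers, but neither gap separates it from the others: a number 3 percentage points higher from compound 2 to compound 3 (within the scatter) and a number 8 percentage points higher from compound 1 to compound 3 (within the scatter) both lie within the scatter, so the three measured compounds are indistinguishable on this read-out.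

Compound 4 `Cc1cc(O)c(C(C)C)cc1-c1cc(-c2ccccc2Cl)c(C#N)c(=O)[nH]1` keeps the shared core and changes only the aryl group in the same position that varies across compounds 1 to 3: 2-chlorophenyl in place of 4-(dimethylamino)phenyl on an aromatic carbon.

Every measured step bears on this position. a number 5 percentage points higher from compound 1 to compound 2 (within the scatter), a number 8 percentage points higher from compound 1 to compound 3 (within the scatter) and a number 3 percentage points higher from compound 2 to compound 3 (within the scatter) each stayed within the scatter, so three different aryl groups at this place gave effectively one number. Compound 4 adds a fourth aryl group at the same place; the expectation is that a number 5 percentage points lower from compound 3 to compound 4 (within the scatter) is likewise no step beyond the scatter, in either direction.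

Compound 4 is therefore estimated at 25% in this assay, with a range from 12% to 38%.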

Compound 4, a percentage reported as inhibition, at one concentration (the size of the read-out at that concentration, not a potency): 12%
Compound 4: middle estimate off by 13 percentage points, on the high side, and the stated range covers the measured number.
By their numbers in this assay, from the lowest: compounds 4, 1, 2 and 3 (each within the scatter of the next, the first and the last beyond it).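

Among the compounds shown here, the position no longer looks flat: in this assay, the change to 2-chlorophenyl gives a number 18 percentage points lower from compound 3 to compound 4 (beyond the scatter) and a number 15 percentage points lower from compound 2 to compound 4 (beyond the scatter), the first steps at this place to pass the scatter. The separation does not extend to the plain phenyl group, since a number 10 percentage points lower from compound 1 to compound 4 (within the scatter) shows that chloro in place of hydrogen on that ring cannot be read as a change on its own, so the series shows a gap between the two ends of the set rather than an effect of the chloro group alone. Nothing available here explains this gap.

Still open, as far as these compounds go, is how a bromo, methyl or carboxylic acid group on this phenyl ring would read, and whether an amine at this place in a non-aryl group would behave like the aryl groups. All these numbers come from one concentration, so they leave the potency of each compound undefined.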